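Working notes: from nitro to methoxy in the series

The source may report more compounds than this note shows. Statements on the series, on what has been measured and on what is new or still open speak of the compounds shown alone.

Measured in a functional assay on HepG2 cells (Homo sapiens) for cytotoxicity, read by MTT assay, with a stated time of 72 h (a lower number here means a stronger inhibitor, a higher number a weaker inhibitor), so far:
- Compound 1 `CCCC[S+]([O-])CCCCN=C=S` gives 5930 nM
- Compound 2 `[O-][S+](CCCCN=C=S)Cc1ccccc1` gives 2850 nM
- Compound 3 `O=[N+]([O-])c1ccc(C[S+]([O-])CCCCN=C=S)cc1` gives 3180 nM

Compound 3 at 3180 nM lies within the scatter of both other measured compounds, nearest to compound 2 and furthest from compound 1.

The next compound is compound 4 `COc1ccc(C[S+]([O-])CCCCN=C=S)cc1`, and the change from compound 3 is methoxy in place of nitro on an aromatic carbon, para to a large group (methoxy in place of nitro on an aromatic carbon).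

Going by the values given here, only one measured step bears on this change. Nitro in place of hydrogen on an aromatic carbon gave a 1.1-fold higher number from compound 2 to compound 3 (0.05 log units; within the scatter) and so stayed within the scatter. Among the compounds with values here, no compound carrying methoxy has been measured, so the data give no direct reading on that group, and the direction stays open. No step beyond the scatter is expected in this assay on this evidence. The expected step is a 1.1-fold lower number from compound 3 to compound 4 (0.03 log units; within the scatter) and it remains an estimate only. For compound 4 the estimated value is 3000 nM with an expected range from 1400 nM to 6500 nM in this measurement.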

Compound 4, half-maximal inhibitory concentration: 4620 nM
The estimate for compound 4 lay 1.5-fold (0.19 log units) below the measured number; the measured number falls inside the stated range.
By their numbers in this assay, from the lowest: compounds 2, 3, 4 and 1 (each within the scatter of the next, the first and the last beyond it).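

In this assay, methoxy on an aromatic carbon, para to a large group, now has its first reading: the change from nitro gives a 1.5-fold higher number from compound 3 to compound 4 (0.16 log units; within the scatter) and the change from hydrogen gives a 1.6-fold higher number from compound 2 to compound 4 (0.21 log units; within the scatter) and neither step leaves the scatter. The earlier compounds held only the nitro-for-hydrogen step at this place, so hydrogen, nitro and methoxy can now be read side by side, and no listed step among the three separates them. This holds only for these three groups on this one aromatic carbon, and no measurement on hand speaks to why the numbers sit as they do.

Going by these compounds, it remains open whether any group at this place can move the number beyond the scatter, and an amine, a carboxylic acid or a fluorine on the same aromatic carbon would put that to the test. On these data alone, it is also open whether a longer chain leading to the isothiocyanate would shift the reading in this assay while the aromatic carbon keeps hydrogen, nitro or methoxy.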